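The compounds below may be only part of what the source reports. "The series", "measured", "known", "first", "only" and "open" are said of these compounds alone.

Compound 1 `O=C([C@H](O)c1ccccc1)N1CC[C@@H]2C[C@@]21C(=O)NCc1cc(Cl)ccc1-n1cnnn1` and compound 2 `O=C(NCc1cc(Cl)ccc1-n1cnnn1)[C@@H]1[C@H]2C[C@H]2CN1C(=O)[C@H](O)c1ccccc1` share the same atoms joined differently; the difference between the two cores is not broken down here. In an ADME assay on liver for metabolic stability, with Liver microsome (Homo sapiens) as the target, read by LC-MS, using microsomes (a lower number here means slower removal, a higher number faster removal of the compound), compound 1 gives 43 mL.min-1.g-1, and compound 2 gives 61 mL.min-1.g-1, a pair that sits within the usual scatter of each other. Compound 3 `CC(C)(C)C[C@@H](O)C(=O)N1C[C@@H]2C[C@@H]2[C@H]1C(=O)NCc1cc(Cl)ccc1-n1cnnn1` is compound 2 with one change, (neopentyl in place of phenyl on a saturated chain carbon bound to a carbonyl carbon and an oxygen on a saturated carbon), and in this assay compound 3 gives 20 mL.min-1.g-1, so that the step of a 3.1-fold lower number from compound 2 to compound 3 (0.48 log units; beyond the scatter) runs toward slower removal.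

Compound 4 `CC(C)(C)C[C@@H](O)C(=O)N1CC[C@@H]2C[C@@]21C(=O)NCc1cc(Cl)ccc1-n1cnnn1` is the same change applied to compound 1, namely (neopentyl in place of phenyl on a saturated chain carbon bound to a carbonyl carbon and an oxygen on a saturated carbon). Within the data shown here, because the only measured example of this change, a 3.1-fold lower number from compound 2 to compound 3 (0.48 log units; beyond the scatter), was modest and beyond the scatter, the step from compound 1 is expected to be of a similar size, a 2.9-fold lower number from compound 1 to compound 4 (0.46 log units; beyond the scatter), and the number for compound 4 in this assay is estimated at 15 mL.min-1.g-1. Allowing for the scatter of this kind of measurement, the value for compound 4 is expected to fall between 7 mL.min-1.g-1 and 30 mL.min-1.g-1.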

Compound 4, intrinsic clearance in microsomes: 27 mL.min-1.g-1
Estimate against measurement, compound 4: 1.8-fold (0.26 log units) below; the range from low to high includes it.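

In this assay, neopentyl in place of phenyl on the core of compound 1 gives a 1.6-fold lower number from compound 1 to compound 4 (0.20 log units; within the scatter), a step that on its own cannot be told apart from the scatter of repeated measurements. Set beside the step on the other core, it shows no measurable difference between the two cores, so the data are consistent with the change carrying across them: the same change on two cores in this assay, a 3.1-fold lower number (0.48 log units; beyond the scatter) from compound 2 to compound 3 and a 1.6-fold lower number (0.20 log units; within the scatter) from compound 1 to compound 4, 1.9-fold (0.28 log units) apart, within the scatter of two such steps. This does not show that the two steps are equal, and only one of them stands clear of the scatter, so the size of the change on the core of compound 1 remains poorly defined.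

The compounds shown leave open whether other groups on this saturated chain carbon, such as a longer chain, an amine or a carboxylic acid, would behave as neopentyl does. They also leave open whether the change would carry to a third core.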